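The source may report more compounds than this note shows. Statements on the series, on what has been measured and on what is new or still open speak of the compounds shown alone.

Among the measured compounds shown here, in a functional assay on MDA-MB-231 cells (Homo sapiens) for cytotoxicity, read by MTT assay, with a stated time of 72 h (a higher number here means that more compound is needed for the effect, a lower number that less compound is needed), compound 1 `CCc1cccc2c(OC)c(-c3occ(C)c3C(=S)OC)ccc12` gives 5.8 ug/mL, the higher of the two numbers so far. Compound 2 `CCOc1c(-c2occ(C)c2CO)ccc2c(CC)cccc12` gives 1.4 ug/mL, a gap beyond the usual scatter. Compound 3 `CCc1cccc2c(OC)c(-c3occ(C)c3CBr)ccc12` keeps the core of compound 1 and changes one group: a group of 2 heavy atoms (1 carbon, 1 bromine; no ring) in place of a group of 4 heavy atoms (2 carbon, 1 oxygen, 1 sulfur; no ring), on an aromatic carbon. For the measured compounds named here, no measured pair shows this change alone, so the expectation rests on thin evidence. A modest fall in the number is expected because compound 2 without the departing group gives 1.4 ug/mL, though it also differs elsewhere. The estimated change is a 2.3-fold lower number from compound 1 to compound 3 (0.37 log units; beyond the scatter). For compound 3 the estimated value is 2.5 ug/mL, within a range from 0.7 ug/mL to 8 ug/mL.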

Compound 3, concentration for half-maximal effect: 4.6 ug/mL
Compound 3: middle estimate off by 1.8-fold (0.26 log units), on the low side; the range from low to high includes it.
By their numbers in this assay, from the lowest: compound 2; then compounds 3 and 1 (each within the scatter of the next).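

On this aromatic carbon of the five-membered ring, swapping the group that holds sulfur and oxygen for bromomethyl gives a step within the scatter in this assay (a 1.3-fold lower number from compound 1 to compound 3 (0.10 log units; within the scatter)). Two groups that differ in size and in their hydrogen-bond acceptors are therefore not told apart at this position by this read-out. Nothing at hand explains this result. Still open, on these data alone, is what an aminomethyl group, a carboxylic acid or a longer chain would give at this position.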